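From benzoyl to propanoyl on compound 2

The source may hold more compounds than are shown below. What is called first, only, known or untested is meant among the compounds shown, and "the series" means these compounds.

Compound 1 `N#Cc1ccc(N2CCC(C(=O)N3N=CC[C@H]3c3cc(F)cc(F)c3)CC2)nn1`: 4.8
Compound 2 `O=C(c1ccccc1)N1CCC(C(=O)N2N=CCC2c2ccccc2)CC1`: 4.4
Compound 3 `CC(C)C(=O)N1N=CCC1c1ccccc1`: 4.4

These three numbers come from a physicochemical assay for lipophilicity, read by HPLC, measured as chromatographic lipophilicity, at pH 7.4; on this read-out lower numbers stand for lower lipophilicity and higher numbers for higher lipophilicity. Compound 2 gives 4.4, level with compound 3 at 4.4 once the usual scatter of repeated measurements is allowed for. Together these two hold the lowest number of the three. The gap between them and compound 1, which gives 4.8, lies beyond the scatter.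

The next compound to be measured is compound 4 `CCC(=O)N1CCC(C(=O)N2N=CCC2c2ccccc2)CC1`. It differs from compound 2 in one place: ethyl in place of phenyl on a carbonyl carbon. Cut one bond further out, the same difference reads benzoyl to propanoyl.

Among the measured compounds shown here, no two measured compounds differ in just one place, so no measured step can serve as a guide here. With a ring of carbon leaving and a shorter chain entering, a modest fall in this assay is expected, and the expected change is a number 0.40 log units lower from compound 2 to compound 4 (beyond the scatter). For the measured compounds named here, that estimate stays cautious and its range is wide, since compound 3 at 4.4 shares the lowest number measured so far. For compound 4 the estimated value is 4, with an expected range from 3.6 to 4.4.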

Compound 4, distribution coefficient: 3.2
Beside the measured number, compound 4's estimate is 0.80 log units above it, outside the stated range (below it).
By their numbers in this assay, from the lowest: compound 4; then compounds 2 and 3 (each within the scatter of the next); then compound 1.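

At this position, the carbonyl carbon attached to an amide-type nitrogen in a ring, the choice of group has a strong effect on the read-out: in this assay, ethyl in place of phenyl gives a number 1.20 log units lower from compound 2 to compound 4 (beyond the scatter) and that step counts as large. Among the compounds shown here, the earlier compounds could not show this, since no two of them differed in just one place, so their numbers could only be set side by side, and this is the first change that can be read on its own. Nothing measured here explains why the step is this large.

This single step removes an aromatic ring and shortens the group at the same time, so the two changes cannot be told apart: cyclohexyl on the same carbonyl carbon would keep a six-membered ring without the aromatic one, while a longer chain such as butyl would keep the group open and add carbon. As far as these compounds go, whether the step keeps its size on other cores also remains open, as it has been read here only once, on the core shared by compound 2 and compound 4.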